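The source may hold more compounds than are shown below. What is called first, only, known or untested is meant among the compounds shown, and "the series" means these compounds.

In a functional assay on NCI-H1299 cells (Homo sapiens) for antiproliferative activity, read by CCK-8 assay, with a stated time of 72 h (a lower number here means a stronger inhibitor, a higher number a weaker inhibitor), compound 2 (`CCOc1cc(C(C)(C)C)ccc1C1=NC(c2ccc(Cl)cc2)C(c2ccc(Cl)cc2)N1C(=O)N1CCN(CCCCCC(=O)NO)CC1`) gives 9390 nM. Compound 3 (`CCOc1cc(C(C)(C)C)ccc1C1=NC(c2ccc(Cl)cc2)C(c2ccc(Cl)cc2)N1C(=O)NCCCCCCCC(=O)NO`) gives 9060 nM, within the scatter of compound 2, while compound 1 (`CCOc1cc(C(C)(C)C)ccc1C1=NC(c2ccc(Cl)cc2)C(c2ccc(Cl)cc2)N1C(=O)NCCCCCCCC(=O)Nc1ccccc1N`), at 19600 nM, shows a higher number than either. Compound 4 (`CCOc1cc(C(C)(C)C)ccc1C1=NC(c2ccc(Cl)cc2)C(c2ccc(Cl)cc2)N1C(=O)N1CCN(CCCCC(=O)NO)CC1`) differs from compound 2 by hydroxycarbamoyl in place of (hydroxycarbamoyl)methyl on a saturated chain carbon, four bonds along the chain from an amine nitrogen in a ring. Within the data shown here, the one measured step, a 2.2-fold lower number from compound 1 to compound 3 (0.34 log units; beyond the scatter), exchanges 2-aminophenyl for hydroxy and leaves this chain untouched. The nearest guide is that the chain of compound 2 differs from that of compound 3, which still stands at 9060 nM. No change beyond the scatter is expected, and the estimated step is a 1.0-fold lower number from compound 2 to compound 4 (0.02 log units; within the scatter). For compound 4 the expected value is 9000 nM, with an estimated range from 4500 nM to 18000 nM.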

Compound 4, half-maximal inhibitory concentration: 12900 nM
Beside the measured number, compound 4's estimate is 1.4-fold (0.16 log units) below it; the range from low to high includes it.
By their numbers in this assay, from the lowest: compounds 3, 2, 4 and 1 (each within the scatter of the next, the first and the last beyond it).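

In this assay, among these compounds, this is the first measured change to the length of the chain itself, since the one earlier step altered only the group on the amide-type nitrogen. Hydroxycarbamoyl in place of (hydroxycarbamoyl)methyl gives a 1.4-fold higher number from compound 2 to compound 4 (0.14 log units; within the scatter) and so, at this position, losing one carbon from the chain produces no change that can be told from the scatter. Nothing measured here offers a reason for this result.

Still open, as far as these compounds go, is whether a longer chain, or a carboxylic acid or an amine at the chain's end in place of hydroxycarbamoyl, would move the number beyond the scatter.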